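This account rests on a few compounds, and the source may have more. Where it says the series, first, only, none or still open, it means among the compounds named here.

Compound 1 `COc1ccc(-c2cs/c(=N\NC(=O)c3ccc(O)cc3)n2-c2ccc(OC)cc2OC)cc1` is one of three compounds tested in a functional assay on OVCAR-3 cells (Homo sapiens) for cytotoxicity, read by sulforhodamine B assay, with a stated time of 48 h; on this read-out higher numbers stand for weaker inhibition of growth and lower numbers for stronger inhibition of growth. In this assay compound 1 gives 3800 nM. Compound 2 `O=C(c1ccc(O)cc1)n1nc(-c2c(Cl)cccc2Cl)sc1=S`, built on a different core, gives 6170 nM, and the two numbers lie within the usual scatter of each other, so no difference between compound 1 and compound 2 can be claimed. Compound 3 `Cc1ccc(-c2cs/c(=N\NC(=O)c3ccc(O)cc3)n2-c2c(C)cccc2C)cc1` carries methyl groups where compound 1 carries methoxy groups; in this assay compound 3 gives 17800 nM. Among the compounds with values here, that number is higher than the one of compound 1 by more than the scatter, so compound 3 inhibits growth more weakly than compound 1.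

Compound 4 `COc1ccc(-n2c(-c3ccc(Cl)cc3)cs/c2=N\NC(=O)c2ccc(O)cc2)c(OC)c1` has not yet been measured. It differs from compound 1 in a single place: chloro in place of methoxy on an aromatic carbon. Within the data shown here, none of the measured pairs shows this particular change, so no measured step can guide the expectation. The step from compound 1 to compound 4 is expected to be small, estimated as a 1.1-fold higher number from compound 1 to compound 4 (0.02 log units; within the scatter), in no clear direction beyond the scatter. For compound 4 the expected value in this assay is 4000 nM, with a range from 1500 nM to 10000 nM.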

Compound 4, concentration for 50% growth inhibition: 26900 nM
For compound 4 the middle estimate is 6.7-fold (0.83 log units) below the measured one, and the stated range ends below it.
By their numbers in this assay, from the lowest: compounds 1 and 2 (each within the scatter of the next); then compounds 3 and 4 (each within the scatter of the next).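

Compound 1 and compound 4 differ in one place only, so this pair gives the first direct reading of a single change among the compounds shown. In this assay, replacing 4-methoxyphenyl with 4-chlorophenyl gives a 7.1-fold higher number from compound 1 to compound 4 (0.85 log units; beyond the scatter), so this position on the ring, para to a large group, is sensitive to the change and growth inhibition weakens beyond the scatter. The data shown offer no measured explanation for this step.

From the compounds shown here alone, with only this one replacement at the position, it remains open whether the step reflects the loss of methoxy, the arrival of chloro, or both. A compound with a hydrogen, a hydroxyl or an amine at the same place would help separate these readings, and a longer ether chain would test how far methoxy itself can be varied.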